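The compounds below may be only part of what the source reports. "The series", "measured", "known", "first", "only" and "open" are said of these compounds alone.

Compound 1 `O=C(Nc1ccc(Cl)cc1)C1CCCN(C(=O)c2cccc(-c3nccs3)c2)C1` gives 32% in an ADME assay on PC-3 cells (Homo sapiens) for cytotoxicity, read by WST assay, tested at 100 uM; on this read-out lower numbers stand for less inhibition and higher numbers for more inhibition at the one concentration tested (going by the name of the read-out). Compound 2 `CC(C)(C)CC(=O)Nc1cccc(C(=O)N2CCCC(C(=O)Nc3ccc(Cl)cc3)C2)c1` stands lowest of the two numbers, giving 0% in this assay, a step of a number 32 percentage points lower from compound 1 to compound 2 (beyond the scatter). Compound 3 `CC(=O)Nc1cccc(C(=O)N2CCCC(C(=O)Nc3ccc(Cl)cc3)C2)c1` differs from compound 2 by hydrogen in place of tert-butyl on a saturated chain carbon bound to a carbonyl carbon. For the measured compounds named here, the only measured step, from compound 1 to compound 2, exchanged a ring for the neopentylcarbonyl amide and does not touch the tert-butyl itself, so it bears on this change only loosely. With compound 2 already at the floor, compound 3 is expected to change by about a number 5 percentage points higher from compound 2 to compound 3 (within the scatter), and its value in this assay is estimated at 5%, within 0% to 20%.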

Compound 3, a percentage reported as inhibition, at one concentration (the size of the read-out at that concentration, not a potency): 4%
Compound 3: the middle estimate sits 1 percentage points above what was measured; measured number inside the range.
By their numbers in this assay, from the lowest: compounds 2 and 3 (each within the scatter of the next); then compound 1.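

Putting hydrogen in place of tert-butyl on a saturated chain carbon bound to a carbonyl carbon gives a number 4 percentage points higher from compound 2 to compound 3 (within the scatter) in this assay and so leaves the read-out within the scatter. The gap to the 1,3-thiazol-2-yl group therefore holds for the short acetamido as well, with a number 28 percentage points lower from compound 1 to compound 3 (beyond the scatter) as the step. Still open, as far as these compounds go, is whether an amine or a carboxylic acid on that chain carbon would read alike, and how a free amino group on the aromatic carbon would compare. No measurement given here accounts for these numbers.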